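Ethyl in place of ring hydrogen across two aryl pairs

The source may report more compounds than this note shows. Statements on the series, on what has been measured and on what is new or still open speak of the compounds shown alone.

Compound 2 `CC1CC(=O)N(CC(=O)N2CCN(c3cccc(C(F)(F)F)c3)CC2)C1=O` gives 100 mg/kg in a functional assay on the whole organism (strain CD1) with Mus musculus as the target, in the maximal electroshock model, with a stated time of 0.5 h; a lower number here means that less compound is needed, a higher number that more compound is needed for the effect. Compound 1 `CCC1(C)CC(=O)N(CC(=O)N2CCN(c3cccc(C(F)(F)F)c3)CC2)C1=O` carries the change ethyl in place of hydrogen on a saturated ring carbon and gives 100 mg/kg in this assay, and the step of no change at the digits printed from compound 2 to compound 1 (within the scatter) is recorded. Compound 3 `CC1CC(=O)N(CC(=O)N2CCN(c3ccc(F)cc3)CC2)C1=O` gives 300 mg/kg in this assay; how its core differs from that of compound 2 is not broken down here. Compound 4 `CCC1(C)CC(=O)N(CC(=O)N2CCN(c3ccc(F)cc3)CC2)C1=O` is not yet measured; relative to compound 3 it carries ethyl in place of hydrogen on a saturated ring carbon, the same change as from compound 2 to compound 1, at the same place in the ring. Because no change at the digits printed from compound 2 to compound 1 (within the scatter) showed no movement, the step of no change at the digits printed from compound 3 to compound 4 (within the scatter) is expected to be small as well. The estimate for compound 4 in this assay is 300 mg/kg, with a range from 100 mg/kg to 600 mg/kg.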

Compound 4, minimum effective dose: 100 mg/kg
Compound 4: the middle estimate sits 3.0-fold (0.48 log units) above what was measured, and the stated range covers the measured number.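

In this assay, ethyl in place of hydrogen on a saturated ring carbon gives a 3.0-fold lower number from compound 3 to compound 4 (0.48 log units; beyond the scatter) and so does not behave alike on the two cores: the same change on two cores in this assay, no change at the digits printed (within the scatter) from compound 2 to compound 1 and a 3.0-fold lower number (0.48 log units; beyond the scatter) from compound 3 to compound 4, 3.0-fold (0.48 log units) apart, beyond the scatter of two such steps. The result is therefore a warning against carrying the size of this step from one core to another in this series, although in neither pair does the change raise the number. Two pairs show no general rule, and they do not show which difference between the cores goes with the difference between the steps.

Open, going by these compounds, is how a propyl chain or a cyclopropyl ring would read in place of ethyl at this ring carbon. Also open, on these data alone, is how the step would read on a core bearing a chlorine or a methoxy group on the aryl ring.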